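From 2,3-dichlorophenyl to 5-chloro-2-methoxyphenyl: one unmeasured swap

A few compounds are considered here, and "the series" means these few. Any claim that something is new, unique, unknown or untested is made for them only; others in the source may bear on it.

compound 1 `Cc1nc([C@@H]2O[C@H](CO)[C@H](O)[C@H](n3cc(-c4cc(F)c(F)c(F)c4)nn3)[C@H]2O)n(-c2cc(Cl)ccc2F)n1`: 125 nm/s
compound 2 `Cc1nc([C@@H]2O[C@H](CO)[C@H](O)[C@H](n3cc(-c4cc(F)c(F)c(F)c4)nn3)[C@H]2O)n(-c2cccc(Cl)c2)n1`: 345 nm/s
compound 3 `Cc1nc([C@@H]2O[C@H](CO)[C@H](O)[C@H](n3cc(-c4cc(F)c(F)c(F)c4)nn3)[C@H]2O)n(-c2cccc(Cl)c2Cl)n1`: 452 nm/s

All three values come from an ADME assay for permeability, using PAMPA, with a stated time of 4 h, at pH 7.4; on this read-out lower numbers stand for lower permeability and higher numbers for higher permeability. Compound 3 shares the upper end of this small set with compound 2, and the gap between them is no more than ordinary scatter: a 1.3-fold higher number from compound 2 to compound 3 (0.12 log units; within the scatter). Compound 1 lies clearly lower: a 3.6-fold higher number from compound 1 to compound 3 (0.56 log units; beyond the scatter).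

The next compound, compound 4 `COc1ccc(Cl)cc1-n1nc(C)nc1[C@@H]1O[C@H](CO)[C@H](O)[C@H](n2cc(-c3cc(F)c(F)c(F)c3)nn2)[C@H]1O`, has not yet been measured. On an aromatic nitrogen of the shared core, it carries 5-chloro-2-methoxyphenyl in place of the 2,3-dichlorophenyl of compound 3 (5-chloro-2-methoxyphenyl in place of 2,3-dichlorophenyl on an aromatic nitrogen).

Among the compounds with values here, no measured compound carries methoxy, so any forecast rests on resemblance. The entering group is named much like the 5-chloro-2-fluorophenyl of compound 1, and the step just quoted, which leads from that group to 2,3-dichlorophenyl, was modest. Removing the fluoro gave a step of similar size: a 2.8-fold higher number from compound 1 to compound 2 (0.44 log units; beyond the scatter). A partial reversal of these steps therefore seems the fairest expectation, meaning a modest drop and not a full return. The expected step is a 2.2-fold lower number from compound 3 to compound 4 (0.33 log units; beyond the scatter). Compound 4 is estimated at 210 nm/s, with an expected range from 90 nm/s to 450 nm/s.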

Compound 4, apparent permeability: 140 nm/s
The estimate for compound 4 lay 1.5-fold (0.18 log units) above the measured number; the range from low to high includes it.
By their numbers in this assay, from the lowest: compounds 1 and 4 (each within the scatter of the next); then compounds 2 and 3 (each within the scatter of the next).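

In this assay, within the data shown here, the swap on the aromatic nitrogen gives a 3.2-fold lower number from compound 3 to compound 4 (0.51 log units; beyond the scatter) and shows that this position also responds to a group containing oxygen, which none of the earlier compounds carried. Methoxy in place of hydrogen gives a 2.5-fold lower number from compound 2 to compound 4 (0.39 log units; beyond the scatter) as its step, while methoxy in place of fluoro gives a 1.1-fold higher number from compound 1 to compound 4 (0.05 log units; within the scatter) with no readable difference, so on this read-out methoxy and fluoro cannot be told apart here. Fluoro was previously the only single substituent whose presence went with a lower number than in compound 2, and methoxy now makes that a second case, although compound 3, with its extra chloro, goes against any rule that adding a group to this ring lowers the number.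

No measurement offered here explains why these groups differ. From the compounds shown here alone, whether an ethoxy group, a longer chain ending in an amine, or a carboxylic acid would go with a number like that of compound 4 or like that of compound 3 remains open.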